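Swapping Acetyl for Hydroxymethyl in a Two-Compound Series

The source may hold more compounds than are shown below. What is called first, only, known or untested is meant among the compounds shown, and "the series" means these compounds.

Measured so far:
compound 1, `N#CCCSC(=S)NCc1cccnc1`, in a functional assay on Bel-7402 cells (Homo sapiens) for cytotoxicity, read by resazurin assay, with a stated time of 72 h; on this read-out higher numbers stand for weaker inhibition and lower numbers for stronger inhibition: 1030 nM
compound 2, `CC(=O)CCSC(=S)NCc1cccnc1`, in this assay: 3430 nM

Going by the values given here, compound 2 stands at the higher of the two numbers, the single measured step being a 3.3-fold higher number from compound 1 to compound 2 (0.52 log units; beyond the scatter). Compound 3, `OCCCSC(=S)NCc1cccnc1`, carries the change (hydroxymethyl in place of acetyl on a saturated chain carbon, two bonds along the chain from a sulfur). That step removes the acetyl that had raised the number, but puts in a hydroxymethyl rather than the cyano of compound 1, so the measured step only partly bears on it. A modest downward step, a 1.5-fold lower number from compound 2 to compound 3 (0.17 log units; within the scatter), is expected, and compound 3 is estimated at 2300 nM, within 700 nM to 8000 nM.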

Compound 3, half-maximal inhibitory concentration: 3650 nM
The estimate for compound 3 lay 1.6-fold (0.20 log units) below the measured number; the measured number falls inside the stated range.
By their numbers in this assay, from the lowest: compound 1; then compounds 2 and 3 (each within the scatter of the next).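

In this assay, hydroxymethyl in place of acetyl on this saturated chain carbon gives a 1.1-fold higher number from compound 2 to compound 3 (0.03 log units; within the scatter), so the step does not separate these two groups. Hydroxymethyl in place of cyano gives a 3.5-fold higher number from compound 1 to compound 3 (0.55 log units; beyond the scatter), which matches the earlier acetyl step in leaving compound 1 alone at the lowest number. Nothing available accounts for this difference. The compounds shown leave open whether an amine, a carboxylic acid or a longer chain here would side with compound 1 or with compound 2 and compound 3.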